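Trimming a Cyclopentyl to Isopropyl on a Shared Core

The compounds below may be only part of what the source reports. "The series", "measured", "known", "first", "only" and "open" are said of these compounds alone.

Compound 1, `CN1CCN(c2ccc(Nc3ncc(/N=C/c4ccc(C(F)(F)F)cc4)c(NC4CCCC4)n3)cc2)CC1`, has been tested in a functional assay on HT-29 cells (Homo sapiens) for antiproliferative activity, read by MTT assay (on this read-out higher numbers stand for weaker inhibition and lower numbers for stronger inhibition), where compound 1 gives 80700 nM. Among the two numbers known in this assay, this is the higher one; compound 2, `CCOC(=O)/C=N/c1cnc(Nc2ccc(S(N)(=O)=O)cc2)nc1NC1CCCC1`, gives 23600 nM. Compound 3, `NS(=O)(=O)c1ccc(Nc2ncc(/N=C/c3ccc(C(F)(F)F)cc3)c(NC3CCCC3)n2)cc1`, reaches only a limit in this assay, namely > 100000 nM; this is a limit of the assay rather than a number, as noted under (the limit of > 100000 nM in this assay, at which 1 of the 3 values shown sits).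

Compound 4, `CC(C)Nc1nc(Nc2ccc(N3CCN(C)CC3)cc2)ncc1/N=C/c1ccc(C(F)(F)F)cc1`, is not yet measured. It differs from compound 1 in one place: isopropyl in place of cyclopentyl on a nitrogen on an aromatic ring. Everything else in the core of compound 1 is kept.

The two measured steps concern other parts of the molecule: an at least 1.2-fold higher number from compound 1 to compound 3 (0.09 log units; that floor lies within the scatter) and an at least 4.2-fold higher number from compound 2 to compound 3 (0.62 log units; beyond the scatter). Neither of them touches the group on the nitrogen where compound 4 changes, so no measured comparison speaks to a cyclopentyl-to-isopropyl swap. Without such evidence, the expected step for compound 4 is none beyond the scatter, a 1.0-fold lower number from compound 1 to compound 4 (0.00 log units; within the scatter). Compound 4 is therefore estimated at 80000 nM, with a range from 25000 nM to 250000 nM, and the chance that only a limit is reported is real given where compound 1 sits.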

Compound 4, half-maximal inhibitory concentration: > 100000 nM
Compound 4: no number, only a limit; the forecaster's own chance of this, stated with the estimate: 35%; middle value at least 1.2-fold (0.09 log units) away from the limit.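

Among these compounds, this is the first measured change to the group on this nitrogen, and in this assay replacing cyclopentylamino with isopropylamino brings no visible gain in inhibition: the step is an at least 1.2-fold higher number from compound 1 to compound 4 (0.09 log units; that floor lies within the scatter). Compound 4 gives > 100000 nM, which is a limit of the assay and not a number. The step is therefore only a floor, so it cannot separate a real loss of activity from no change at all, and the series now has a second compound at this same limit: the limit of > 100000 nM in this assay, at which 2 of the 4 values shown sit.

The compounds shown leave open whether a cyclohexyl ring or an aminoethyl chain on this nitrogen would bring the value of the piperazine-bearing compounds down into the range where it can be read as a number. They also leave open whether isopropyl in place of cyclopentyl would have a measurable effect on compound 2, which gives 23600 nM and so, unlike compound 3 and compound 4, has a number from which a step in either direction could be read.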